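Swapping the aryl group on the piperazine of compound 2

The source may hold more compounds than are shown below. What is called first, only, known or untested is meant among the compounds shown, and "the series" means these compounds.

Of the compounds shown here, two sharing one core have been measured. Compound 1 `CCCc1nc(-c2ccccc2)c(CNCCCN2CCN(c3ccccc3Cl)CC2)o1` gives 64.7% in an assay on HEK293 cells for inhibition of Voltage-dependent T-type calcium channel subunit alpha-1G (Homo sapiens), read by fluorescence, tested at 10 uM; on this read-out higher numbers stand for more inhibition at the one concentration tested (going by the name of the read-out) and lower numbers for less inhibition. Within the data shown here, compound 2 `CCCc1nc(-c2ccccc2)c(CNCCCN2CCN(c3ccccc3OC)CC2)o1` gives 41% in this assay, which is the lower of the two numbers; the only step measured so far is a number 23.7 percentage points lower from compound 1 to compound 2 (beyond the scatter), showing that the group carried on the aromatic ring attached to the ring nitrogen moves the read-out well beyond the scatter.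

Compound 3 `CCCc1nc(-c2ccccc2)c(CNCCCN2CCN(c3ccc(C)cc3)CC2)o1` has not yet been tested. It differs from compound 2 by 4-methylphenyl in place of 2-methoxyphenyl on an amine nitrogen in a ring. Among the measured compounds shown here, no measured step covers this exact exchange: the one available step changed only a single substituent at one spot on that ring, whereas here both the substituent and its place on the ring change. That step therefore bears on compound 3 only loosely, indicating that a change of this sort can move inhibition by a modest amount in either direction. For compound 3 the expected result is 50%, within a range of 25% to 75%. For the measured compounds named here, because a number 23.7 percentage points lower from compound 1 to compound 2 (beyond the scatter) is the only guide, the expected step of a number 9 percentage points higher from compound 2 to compound 3 (within the scatter) is estimated with wide uncertainty.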

Compound 3, a percentage reported as inhibition, at one concentration (the size of the read-out at that concentration, not a potency): 53.9%
Beside the measured number, compound 3's estimate is 3.9 percentage points below it; low and high end bracket the measured number.
By their numbers in this assay, from the lowest: compound 2; then compound 3; then compound 1.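

Placing 4-methylphenyl on the amine nitrogen in the ring gives a number 12.9 percentage points higher from compound 2 to compound 3 (beyond the scatter), so this position still responds clearly when both the substituent and its place on the aromatic ring change. The same group also gives a number 10.8 percentage points lower from compound 1 to compound 3 (beyond the scatter), which leaves all three compounds apart from one another beyond the scatter in this assay, with 4-methylphenyl between 2-methoxyphenyl and 2-chlorophenyl. Each exchange alters the substituent and its place on the aromatic ring together, so neither step can be split into those two parts, and nothing measured here accounts for the differences between the three aryl groups.

On these data alone, whether the substituent or its place on the aromatic ring matters more remains open, and 2-methylphenyl or 4-chlorophenyl on the same nitrogen would allow those two changes to be looked at separately. Also open is how an unsubstituted phenyl group on that nitrogen compares with these three, since each aromatic ring shown here carries a substituent, and these single-concentration percentages say nothing on their own about potency.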